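The source may hold more compounds than are shown below. What is called first, only, known or untested is meant among the compounds shown, and "the series" means these compounds.

Measured so far:
- compound 1, `Cc1cccc2[nH]c(-c3n[nH]c4ncc(-c5cncc6ccccc56)cc34)nc12`: 3090 nM
- compound 2, `CN1CCN(c2ccc3[nH]c(-c4n[nH]c5ncc(-c6cncc7ccccc67)cc45)nc3c2)CC1`: 450 nM

Among the compounds with values here, in a functional assay on HeLa cells (Homo sapiens) for antiproliferative activity (a higher number here means a weaker inhibitor, a lower number a stronger inhibitor), compound 1 gives 3090 nM, the higher of the two numbers known; compound 2, which carries a different group on the same ring of the shared core, gives 450 nM, a gap well beyond the scatter, though no single-change step links these two compounds.

Compound 3, `CC(C)NCc1cccc2[nH]c(-c3n[nH]c4ncc(-c5cncc6ccccc56)cc34)nc12`, differs from compound 1 by isopropylamino in place of hydrogen on a saturated chain carbon bound to an aromatic carbon. Within the data shown here, no measured pair shows this exact change, so its size is uncertain. Because compound 2 with its different substituent gives 450 nM, a lower number than compound 1, a modest drop in the number is expected for compound 3 as well, though a change within the scatter cannot be ruled out. The expected step is a 3.1-fold lower number from compound 1 to compound 3 (0.49 log units; beyond the scatter). Compound 3 is therefore estimated at 1000 nM, with a likely range from 300 nM to 3500 nM.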

Compound 3, half-maximal inhibitory concentration: 130 nM
For compound 3 the middle estimate is 7.7-fold (0.89 log units) above the measured one; the measured number lies below the stated range.
By their numbers in this assay, from the lowest: compound 3; then compound 2; then compound 1.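

Placing isopropylamino in place of hydrogen on a saturated chain carbon bound to an aromatic carbon gives a 24-fold lower number from compound 1 to compound 3 (1.38 log units; beyond the scatter) in this assay, the only single-change step among these compounds. This shows that the position is far from silent: going from methyl to (isopropylamino)methyl moves the number well beyond the scatter, and in the direction of a stronger inhibitor, so this larger group is tolerated here. No measurement at hand bears on why the number falls.

The compounds shown leave open whether the step depends on the nitrogen, on the isopropyl part or on both, which a hydroxymethyl, an aminomethyl or a cyclopropylaminomethyl group at the same place could help to separate. One step on one pair also cannot show whether the same change would act alike on a different core.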